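This account rests on a few compounds, and the source may have more. Where it says the series, first, only, none or still open, it means among the compounds named here.

Measured so far: compound 1 `O=S(=O)(c1cccc(F)c1)c1ccc2c(c1)CCC[C@H]2CN1CCCS1(=O)=O` gives 31.6 nM in an assay on isolated protein for displacement of a labelled ligand from 5-hydroxytryptamine receptor 6 (Homo sapiens); a lower number here means a stronger inhibitor, a higher number a weaker inhibitor; compound 2 `O=C(NC[C@@H]1CCCc2cc(S(=O)(=O)c3cccc(F)c3)ccc21)[C@H]1CCCN1` gives 0.631 nM in this assay. Compound 2 stands at the lowest number of the two, with compound 1 the nearest point, as a 50-fold lower number from compound 1 to compound 2 (1.70 log units; beyond the scatter) shows. Compound 3 `O=S(=O)(c1cccc(F)c1)c1ccc2c(c1)CCC[C@H]2CN1CC(O)C1` carries 3-hydroxyazetidin-1-yl in place of ((pyrrolidin-2-yl)carbonyl)amino on a saturated chain carbon bound to a saturated ring carbon. Going by the values given here, only the step from compound 1 to compound 2 bears on this position, and it was large. The group entering in compound 3 is smaller than either earlier group there, so a step back toward compound 1 is expected, but not all the way. For compound 3 the expected value in this assay is 5 nM (range 1 nM to 30 nM), an estimated step of a 7.9-fold higher number from compound 2 to compound 3 (0.90 log units; beyond the scatter).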

Compound 3, inhibition constant: 0.1 nM
For compound 3 the middle estimate is 50-fold (1.70 log units) above the measured one; measured number outside the range, below it.
By their numbers in this assay, from the lowest: compound 3; then compound 2; then compound 1.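

Replacing ((pyrrolidin-2-yl)carbonyl)amino with 3-hydroxyazetidin-1-yl gives a 6.3-fold lower number from compound 2 to compound 3 (0.80 log units; beyond the scatter) in this assay and shows that neither the carbonyl nor the pyrrolidine ring is required for a low number at this position. Against compound 1 the change gives a 320-fold lower number from compound 1 to compound 3 (2.50 log units; beyond the scatter) and is the largest step seen here. Heavy-atom count does not order the three: compound 3 has the smallest group and the lowest number, compound 1 the mid-sized group and the highest number, and no measurement at hand explains this.

Still open, as far as these compounds go, is whether the hydroxyl or the four-membered ring carries the gain. Azetidin-1-yl, 3-methoxyazetidin-1-yl or 3-hydroxypyrrolidin-1-yl at this position would separate the two.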